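Swapping cyclohexyl for 4-fluorophenyl on the pyridine-type core

The compounds below may be only part of what the source reports. "The series", "measured", "known", "first", "only" and "open" are said of these compounds alone.

Measured so far:
compound 1 `COc1nc(C2CCCCC2)ccc1[C@@H](c1ccccc1)[C@@](O)(CCN(C)C)c1cccc2ccccc12`: 57.7 ug/mL
compound 2 `COc1ncc(-c2ccccc2)cc1[C@@H](c1ccccc1)[C@@](O)(CCN(C)C)c1cc(F)ccc1F`: "nd" (no result reported)
compound 3 `COc1ncc(-c2ccccc2)cc1[C@@H](c1ccccc1)[C@@](O)(CCN(C)C)c1cc(F)cc(F)c1`: 28.8 ug/mL

Within the data shown here, in a toxicity assay on HeLa cells (Homo sapiens) for cytotoxicity (on this read-out higher numbers stand for lower toxicity in this test and lower numbers for higher toxicity in this test), compound 1 gives 57.7 ug/mL, the top of the two known numbers, though compound 3 with 28.8 ug/mL lies within the usual scatter of it, so no order between them can be claimed. For compound 2 no result was reported in this assay.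

Compound 4 `COc1nc(-c2ccc(F)cc2)ccc1[C@@H](c1ccccc1)[C@@](O)(CCN(C)C)c1cccc2ccccc12` keeps the core of compound 1 and differs in one place: 4-fluorophenyl in place of cyclohexyl on an aromatic carbon. Among the measured compounds shown here, no step between measured compounds tells what such a change does in this assay, so nothing beyond the scatter is expected in either direction. Compound 4 is therefore estimated at 45 ug/mL, between 20 ug/mL and 100 ug/mL, which would mean a step of a 1.3-fold lower number from compound 1 to compound 4 (0.11 log units; within the scatter).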

Compound 4, half-maximal cytotoxic concentration: > 64 ug/mL
Compound 4 ended at the assay's limit (the forecaster's own chance of this, stated with the estimate: 10%); middle value at least 1.4-fold (0.15 log units) from the limit.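

In this assay compound 4 reaches a limit of the assay, not a number: the limit of > 64 ug/mL in this assay, at which 1 of the 4 values shown sits. Placing 4-fluorophenyl in place of cyclohexyl next to the ring nitrogen gives an at least 1.1-fold higher number from compound 1 to compound 4 (0.04 log units; that floor lies within the scatter). This position therefore accepts an aromatic ring with no sign of higher toxicity in this test, though the true size of the step cannot be read.

The compounds shown leave open what an unsubstituted phenyl, an amine or a carboxylic acid at this position would give in this assay. From the compounds shown here alone, whether the fluorine of the 4-fluorophenyl group plays any part also remains open.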